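Adding one methoxy group to compound 2

A few compounds are considered here, and "the series" means these few. Any claim that something is new, unique, unknown or untested is made for them only; others in the source may bear on it.

Compound 1 `COc1ccc(/C=C/C(=O)N2CCC=CC2=O)c(OC)c1`: 8500 nM
Compound 2 `COc1ccc(/C=C/C(=O)N2CCC=CC2=O)cc1OC`: 3700 nM

Both compounds were tested in a functional assay on MCF7 cells (Homo sapiens) for antiproliferative activity, read by resazurin assay, with a stated time of 48 h; on this read-out higher numbers stand for weaker inhibition and lower numbers for stronger inhibition. Compound 2 gives 3700 nM as the lower of the two numbers, and compound 1 gives 8500 nM as the higher, a gap beyond the usual scatter. Compound 2 is thus the stronger inhibitor of this pair.

Compound 3 `COc1cc(OC)c(OC)cc1/C=C/C(=O)N1CCC=CC1=O` has not yet been measured. It differs from compound 2 in one place, with methoxy in place of hydrogen on an aromatic carbon. Among the compounds with values here, no measured pair here differs in a single place, so the data offer no direct guide to this change. The expected change a 1.1-fold lower number from compound 2 to compound 3 (0.02 log units; within the scatter) is small, has no firm direction and stays within the scatter. Compound 3 is estimated at 3500 nM in this assay with an expected range from 1400 nM to 9000 nM for repeated measurements.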

Compound 3, half-maximal inhibitory concentration: 3400 nM
For compound 3 the middle estimate is 1.0-fold (0.01 log units) above the measured one; the measured number falls inside the stated range.
By their numbers in this assay, from the lowest: compounds 3 and 2 (each within the scatter of the next); then compound 1.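

In this assay, methoxy in place of hydrogen on this aromatic carbon, ortho to a large group, meta to a methoxy group and para to a methoxy group, gives a 1.1-fold lower number from compound 2 to compound 3 (0.04 log units; within the scatter) and so leaves the number of compound 2 essentially unchanged. The same kind of replacement gives a 2.5-fold lower number from compound 1 to compound 3 (0.40 log units; beyond the scatter) and so separates compound 3 from compound 1, which shows that the outcome of adding a methoxy group depends on the compound that receives it. Nothing available here explains why these two steps differ.

The compounds shown leave open whether this position would tolerate a group other than methoxy, such as an amine, a chlorine atom or a longer ether chain. They also leave open whether a step of similar size would appear in other cell lines.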